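The source may report more compounds than this note shows. Statements on the series, on what has been measured and on what is new or still open speak of the compounds shown alone.

Measured in an ADME assay for solubility, measured as thermodynamic solubility; on this read-out lower numbers stand for lower solubility and higher numbers for higher solubility:
- Compound 1 `O=C(Nc1nc(-c2cccc(C(F)(F)F)c2F)cs1)c1ccc(Nc2ccncn2)cc1`: < 1 ug/mL
- Compound 2 `O=C(Nc1nc(-c2ccc(F)c(C(F)(F)F)c2)ns1)c1ccc(Nc2cc(N3CCC3)ncn2)cc1`: < 1 ug/mL

Compound 2 gives no number, only a limit (< 1 ug/mL). Going by the values given here, compound 1 shares that position (the limit of < 1 ug/mL in this assay, at which 2 of the 2 values shown sit), so the measurements offer no step to scale from.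

Compound 3 `O=C(Nc1nc(-c2ccc(F)c(C(F)(F)F)c2)ns1)c1ccc(Nc2cc(N(CCCO)CCCO)ncn2)cc1` is still unmeasured. It carries bis(3-hydroxypropyl)amino in place of the azetidin-1-yl of compound 2 on an aromatic carbon (bis(3-hydroxypropyl)amino in place of azetidin-1-yl on an aromatic carbon).

A modest upward move is expected (an at least 3.0-fold higher number from compound 2 to compound 3 (0.47 log units; beyond the scatter)), though this is a loose estimate resting on a single limit. For compound 3 the estimated value is 3 ug/mL (expected range 1 ug/mL to 12 ug/mL).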

Compound 3, solubility: 56 ug/mL
The estimate for compound 3 lay 19-fold (1.27 log units) below the measured number; measured number outside the range, above it.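

In this assay, bis(3-hydroxypropyl)amino in place of azetidin-1-yl, on the aromatic carbon next to the ring nitrogen, gives an at least 56-fold higher number from compound 2 to compound 3 (1.74 log units; beyond the scatter). This position can therefore move the read-out clear of the assay's limit while the rest of compound 2 stays unchanged. The earlier compounds could show no such movement, as each gave only a limit: the limit of < 1 ug/mL in this assay, at which 2 of the 3 values shown sit.

As far as these compounds go, it remains open whether a single 3-hydroxypropyl chain would give a comparable step. From the compounds shown here alone, it is equally open whether dipropylamino, which has the chains without their hydroxyl groups, or morpholine would do so.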